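Chloroacetamide replacement on the shared core: cytotoxicity notes

The source may hold more compounds than are shown below. What is called first, only, known or untested is meant among the compounds shown, and "the series" means these compounds.

Measured compounds:
compound 1 `Cn1c(-c2ccc(NC(=O)CCl)cc2)nc(-c2ccccc2)c1-c1ccccc1` — 70%
compound 2 `Cn1c(-c2ccc(NC(=O)CSc3nc4ccccc4o3)cc2)nc(-c2ccccc2)c1-c1ccccc1` — 76.3%
compound 3 `Cn1nnnc1SCC(=O)Nc1ccc(-c2nc(-c3ccccc3)c(-c3ccccc3)n2C)cc1` — 77.7%

All three were read in a functional assay on MCF7 cells (Homo sapiens) for cytotoxicity, read by MTT assay, with a stated time of 24 h, tested at 80 ug/mL; a lower number here means a weaker effect, a higher number a stronger effect of the compound at the concentration tested. Compound 1 gives 70%, the lowest of the three numbers; compound 2 and compound 3 both sit within the scatter of it, so no order can be drawn among them.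

Compound 4 `Cn1c(-c2ccc(NC(=O)CN3CCN(c4ccccc4)CC3)cc2)nc(-c2ccccc2)c1-c1ccccc1` is not yet measured. It differs from compound 1 as follows: 4-phenylpiperazin-1-yl in place of chloro on a saturated chain carbon bound to a carbonyl carbon.

Among the measured compounds shown here, the steps that bear on this change are those at the same place on compound 1: a number 6.3 percentage points higher from compound 1 to compound 2 (within the scatter) and a number 7.7 percentage points higher from compound 1 to compound 3 (within the scatter). Both are within the scatter, whichever group replaces the chloro on the saturated chain carbon bound to the carbonyl carbon. For compound 4 the expected step is therefore a number 4 percentage points higher from compound 1 to compound 4 (within the scatter), not beyond the scatter, because the two measured steps of a number 6.3 percentage points higher from compound 1 to compound 2 (within the scatter) and a number 7.7 percentage points higher from compound 1 to compound 3 (within the scatter) showed nothing larger.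

Compound 4 is thus estimated at 74%, with an expected range from 60% to 88%.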

Compound 4, a percentage reported as activity, at one concentration (the size of the read-out at that concentration, not a potency): 72.5%
Compound 4: middle estimate off by 1.5 percentage points, on the high side, within the range that was stated.
By their numbers in this assay, from the lowest: compounds 1, 4, 2 and 3 (each within the scatter of the next).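

In this assay, the 4-phenylpiperazin-1-yl group, with 12 heavy atoms and two six-membered rings, replaces the single chlorine on the saturated chain carbon bound to a carbonyl carbon, and the result is a number 2.5 percentage points higher from compound 1 to compound 4 (within the scatter). This extends the flat picture at this place to a group joined through a piperazine nitrogen rather than a sulfur, since the comparisons with the two sulfanyl groups give a number 3.8 percentage points lower from compound 2 to compound 4 (within the scatter) and a number 5.2 percentage points lower from compound 3 to compound 4 (within the scatter), so no order can be drawn among these replacements. No available evidence bears on this result.

As far as these compounds go, whether a morpholine, a carboxylic acid or a longer chain at this place would give a step beyond the scatter remains open. A read-out at one concentration also leaves the potency of all four compounds open.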